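Amide substituent swap at the piperidine nitrogen: acid to piperidine

A few compounds are considered here, and "the series" means these few. Any claim that something is new, unique, unknown or untested is made for them only; others in the source may bear on it.

Two compounds of the series have numbers in an assay on isolated protein for displacement of a labelled ligand from secreted frizzled-related protein 1 (Homo sapiens), read by fluorescence polarization, with a stated time of 30 min; on this read-out higher numbers stand for weaker inhibition and lower numbers for stronger inhibition. Compound 1 `O=C(c1ccc(Cl)cc1)N1CCC(NS(=O)(=O)c2cc(S(=O)(=O)c3ccccc3)ccc2C(F)(F)F)CC1` gives 300 nM. For the measured compounds named here, compound 2 `O=C(O)CCCC(=O)N1CCC(NS(=O)(=O)c2cc(S(=O)(=O)c3ccccc3)ccc2C(F)(F)F)CC1` gives 500 nM; it has the higher of the two numbers, but the only measured step, a 1.7-fold higher number from compound 1 to compound 2 (0.22 log units; within the scatter), lies within the scatter, so the two compounds cannot be told apart on these data.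

Compound 3 `O=C(CC1CCNCC1)N1CCC(NS(=O)(=O)c2cc(S(=O)(=O)c3ccccc3)ccc2C(F)(F)F)CC1` differs from compound 2 in one place: piperidin-4-yl in place of 2-carboxyethyl on a saturated chain carbon bound to a carbonyl carbon. Going by the values given here, no measured step bears on this exchange; the single step known, from an aryl group to an acid chain on the carbonyl carbon, changed the number only within the scatter, and it concerns a different pair of groups. There is therefore no basis to expect a step beyond the scatter in either direction in this assay for compound 3, and the uncertainty is wider than for a change already sampled.

The expected step is no change at the digits printed from compound 2 to compound 3 (within the scatter), meaning no change beyond the scatter. Compound 3 is estimated at 500 nM, within a range from 170 nM to 1500 nM.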

Compound 3, half-maximal inhibitory concentration: 100 nM
Beside the measured number, compound 3's estimate is 5.0-fold (0.70 log units) above it; measured number outside the range, below it.
By their numbers in this assay, from the lowest: compound 3; then compounds 1 and 2 (each within the scatter of the next).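

In this assay, for the compounds shown here, the place on a saturated chain carbon bound to a carbonyl carbon responds to the group it carries: piperidin-4-yl in place of 2-carboxyethyl gives a 5.0-fold lower number from compound 2 to compound 3 (0.70 log units; beyond the scatter), the first step beyond the scatter. Compound 3 also separates from the aryl member, as (piperidin-4-yl)methyl in place of 4-chlorophenyl on a carbonyl carbon gives a 3.0-fold lower number from compound 1 to compound 3 (0.48 log units; beyond the scatter), whereas compound 1 and compound 2 could not be told apart. Nothing at hand speaks to the reason for either step.

The exchange brings in a ring and a ring nitrogen together, so the compounds shown do not say which of the two goes with the lower number. A cyclohexyl group at this place would keep the ring without the nitrogen, and an open-chain amine such as 3-aminopropyl would keep the nitrogen without the ring, so the pair would part the two contributions.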